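The source may report more compounds than this note shows. Statements on the series, on what has been measured and on what is new or still open speak of the compounds shown alone.

Measured so far in an assay on CHO-K1 cells for displacement of a labelled ligand from adenosine receptor A1 (Homo sapiens), read by scintillation counting, with a stated time of 60 min; on this read-out higher numbers stand for weaker inhibition and lower numbers for stronger inhibition:
compound 1, `Nc1nc(N/N=C/c2ccc(-c3ccc(Br)cc3)o2)nc2c1ncn2[C@@H]1O[C@H](CO)[C@@H](O)[C@H]1O`, gives 4.5 nM
compound 2, `Nc1nc(N/N=C/c2ccc(Cl)c(C(F)(F)F)c2)nc2c1ncn2[C@@H]1O[C@H](CO)[C@@H](O)[C@H]1O`, gives > 10000 nM

Among the measured compounds shown here, compound 1 supplies the one numerical reading of the pair. For compound 2 the result is only a limit of the assay, > 10000 nM, and no number was obtained (the limit of > 10000 nM in this assay, at which 1 of the 2 values shown sits). For the measured compounds named here, compound 2 therefore stands at the weak end of what this assay reports, and since no step between the two measured compounds has been worked out, the two readings can only be set side by side.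

The unmeasured compound 3, `CC(=O)Nc1ccc(/C=N/Nc2nc(N)c3ncn([C@@H]4O[C@H](CO)[C@@H](O)[C@H]4O)c3n2)cc1`, keeps the shared core of compound 2 and alters the group on a carbon with a double bond to nitrogen: 4-acetamidophenyl in place of 4-chloro-3-(trifluoromethyl)phenyl on a carbon with a double bond to nitrogen. Going by the values given here, no step of this kind has been measured, so its direction rests on expectation alone; the orientation comes from the strong reading of compound 1 and the limit of compound 2. For compound 3 a gain on compound 2 is expected, of the size given by an at least 3.3-fold lower number from compound 2 to compound 3 (0.52 log units; beyond the scatter), with wide uncertainty. The estimate for compound 3 is 3000 nM, within a range from 500 nM to 10000 nM.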

Compound 3, inhibition constant: > 10000 nM
Compound 3 gave a limit, no number (the forecaster's own chance of this, stated with the estimate: 35%); middle value at least 3.3-fold (0.52 log units) away from the limit.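

In this assay compound 3 gives only a limit, > 10000 nM. Compound 2 also stands at a limit, so no step from compound 2 to compound 3 can be read: the limit of > 10000 nM in this assay, at which 2 of the 3 values shown sit.

The compounds shown leave open whether 4-acetamidophenyl or 4-chloro-3-(trifluoromethyl)phenyl gives the stronger inhibition.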